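Compound 4: a new aryl group on the thiourea

The source may report more compounds than this note shows. Statements on the series, on what has been measured and on what is new or still open speak of the compounds shown alone.

Measured in a functional assay on T98G cells (Homo sapiens) for inhibition, read by MTT assay, with a stated time of 72 h; on this read-out lower numbers stand for stronger inhibition and higher numbers for weaker inhibition:
- compound 1 `CC1(C)CC(NC(=S)Nc2cccc(C#N)c2)c2cc(Br)ccc2O1` gives 9000 nM
- compound 2 `CC1(C)CC(NC(=S)Nc2cccc(C#N)c2)c2cc(F)ccc2O1` gives 39000 nM
- compound 3 `CC1(C)CC(NC(=S)Nc2cccc(C#N)c2)c2cc(Cl)ccc2O1` gives 10000 nM

Compound 1 and compound 3 cannot be told apart, with a 1.1-fold higher number from compound 1 to compound 3 (0.05 log units; within the scatter). Compound 2 stands on the weaker side of both, with a 4.3-fold higher number from compound 1 to compound 2 (0.64 log units; beyond the scatter) and a 3.9-fold lower number from compound 2 to compound 3 (0.59 log units; beyond the scatter). Compound 1 therefore belongs to the stronger pair of this small set.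

The next compound, compound 4 `CC1(C)CC(NC(=S)Nc2ccccc2Cl)c2cc(Br)ccc2O1`, keeps the bromo core of compound 1 and changes the other end of the molecule, with 2-chlorophenyl in place of 3-cyanophenyl on an amide-type nitrogen. The counted difference is 2-chlorophenyl in place of 3-cyanophenyl on an amide-type nitrogen.

Among the compounds with values here, none of the measured steps touches this position. All three exchange bromo, chloro and fluoro on an aromatic carbon while 3-cyanophenyl stays fixed, so they give no direction for the new change. They offer only a rough sense of size, since the largest is the modest 4.3-fold higher number from compound 1 to compound 2 (0.64 log units; beyond the scatter). In this assay, a modest step in either direction is therefore conceivable, but no step beyond the scatter is the central expectation. The expected step is a 1.1-fold higher number from compound 1 to compound 4 (0.05 log units; within the scatter). Compound 4 is estimated at 10000 nM, with an expected range from 3000 nM to 35000 nM.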

Compound 4, half-maximal inhibitory concentration: 8000 nM
For compound 4 the middle estimate is 1.3-fold (0.10 log units) above the measured one; low and high end bracket the measured number.
By their numbers in this assay, from the lowest: compounds 4, 1 and 3 (each within the scatter of the next); then compound 2.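

In this assay, within the data shown here, the change at the amide-type nitrogen gives a 1.1-fold lower number from compound 1 to compound 4 (0.05 log units; within the scatter) and so provides the first reading at this position, which the halogen steps left untouched: on the bromo core, 2-chlorophenyl and 3-cyanophenyl cannot be told apart. The exchange removes the nitrile, with the one hydrogen-bond acceptor counted on the leaving group, and brings in a chlorine, yet the number does not move beyond the scatter, so in this pair the nitrile is not needed to hold this level of inhibition. Nothing available accounts for the two aryl groups reading alike.

Among these compounds, compound 1 and compound 4 are the only pair that compares aryl groups here, so they cannot separate the loss of the nitrile from the gain of the chlorine, or show what the placing of either group on the ring contributes. Going by these compounds, it remains open whether a plain phenyl, a methoxyphenyl or a cyclohexyl would hold the same level, and whether 2-chlorophenyl would match 3-cyanophenyl on the chloro and fluoro cores of compound 3 and compound 2.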